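The compounds below may be only part of what the source reports. "The series", "measured", "known", "first", "only" and "open" are said of these compounds alone.

Of the compounds shown here, three of one shared core have been tested in a functional assay on NCI-H292 cells (Homo sapiens) for cytotoxicity, read by MTT assay, with a stated time of 72 h, tested at 1.25 ug/mL; a lower number here means less inhibition of growth, a higher number more inhibition of growth at the concentration tested. Compound 1 `O=C1NC(=S)/C(=C/c2cccc(Cl)c2)S1` gives 3.35%, compound 2 `O=C1NC(=S)/C(=C/c2cccc(F)c2)S1` gives 2.1%, and compound 3 `O=C1NC(=S)/C(=C/c2ccc(Cl)c(Cl)c2)S1` gives 9.18%. Compound 2 thus shows the lowest of the three numbers, though its gaps to compound 1 and to compound 3 both fall within the usual scatter of such measurements, so the three cannot be told apart with confidence.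

Compound 4 `O=C1NC(=S)/C(=C/c2cccc(Br)c2)S1` has not yet been measured. It differs from compound 2 in one place: bromo in place of fluoro on an aromatic carbon. The step that bears most directly on this change is the exchange of one halogen for another at the same place, seen from compound 1 to compound 2, where a number 1.3 percentage points lower from compound 1 to compound 2 (within the scatter). The other step, chloro in place of hydrogen, gave a number 5.8 percentage points higher from compound 1 to compound 3 (within the scatter). Neither step moved the number beyond the scatter, so swapping fluoro for bromo is expected to leave the number essentially where it is. Compound 4 is therefore estimated to give 3.5% in this assay, within a range of -5% to 12%, which corresponds to an expected step of a number 1.4 percentage points higher from compound 2 to compound 4 (within the scatter).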

Compound 4, percent growth inhibition at one concentration: 4.67%
Compound 4: middle estimate off by 1.2 percentage points, on the low side, within the range that was stated.
By their numbers in this assay, from the lowest: compounds 2, 1, 4 and 3 (each within the scatter of the next).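

In this assay the same spot on the aromatic ring has now carried fluoro, chloro and bromo, which allows a full comparison of these three halogens: bromo in place of fluoro gives a number 2.6 percentage points higher from compound 2 to compound 4 (within the scatter) and bromo in place of chloro gives a number 1.3 percentage points higher from compound 1 to compound 4 (within the scatter) as well. Together with the earlier exchange of chloro for fluoro, every pair among these three compounds has now been compared, and no pair can be told apart at the single concentration tested, so this set gives no sign that the choice among these halogens matters here. No measurement shown here offers an explanation for this result.

Every compound shown carries a halogen on the ring, so the effect of a quite different group at this spot, such as an amine, a carboxylic acid or a longer chain, remains open. As far as these compounds go, all the numbers also lie close together in a single cell line at one concentration, so whether these halogens would separate at other concentrations, or with bromo placed elsewhere on the ring, also remains open.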